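Halogen swap on the para-substituted aryl across two anilines

The source may hold more compounds than are shown below. What is called first, only, known or untested is meant among the compounds shown, and "the series" means these compounds.

Compound 1 `COc1ccc(N/C=C\C(=O)c2cn(-c3ccccc3)nc2-c2ccc(F)cc2)cc1` gives 8900 nM in a functional assay on A549 cells (Homo sapiens) for antiproliferative activity, read by MTT assay, with a stated time of 48 h; a higher number here means a weaker inhibitor, a lower number a stronger inhibitor. Compound 3 `COc1ccc(N/C=C\C(=O)c2cn(-c3ccccc3)nc2-c2ccc(Cl)cc2)cc1` differs from compound 1 by chloro in place of fluoro on an aromatic carbon; in this assay compound 3 gives 6460 nM, so that a 1.4-fold lower number from compound 1 to compound 3 (0.14 log units; within the scatter). Compound 2 `COc1cc(N/C=C\C(=O)c2cn(-c3ccccc3)nc2-c2ccc(F)cc2)cc(OC)c1OC` carries a different aniline part; the difference between its core and that of compound 1 is not broken down here. In this assay compound 2 gives 9350 nM. Compound 4 `COc1cc(N/C=C\C(=O)c2cn(-c3ccccc3)nc2-c2ccc(Cl)cc2)cc(OC)c1OC` is the unmeasured partner of compound 2, differing from it by chloro in place of fluoro on an aromatic carbon. Among the compounds with values here, the place is described in the same words for both pairs, so this is the same change as the one from compound 1 to compound 3. The pair of measured numbers shows only a step within the scatter, and nothing in the three measured compounds points to a different outcome on the other core; the expected step is a 1.4-fold lower number from compound 2 to compound 4 (0.14 log units; within the scatter), set beside a 1.4-fold lower number from compound 1 to compound 3 (0.14 log units; within the scatter) because compound 2 starts from 9350 nM. For compound 4 the estimate is 6800 nM, expected to fall between 3400 nM and 13600 nM.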

Compound 4, half-maximal inhibitory concentration: 5640 nM
The estimate for compound 4 lay 1.2-fold (0.08 log units) above the measured number, within the range that was stated.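

In this assay, chloro in place of fluoro on an aromatic carbon gives a 1.7-fold lower number from compound 2 to compound 4 (0.22 log units; within the scatter). Set beside the same change on the other core, the two steps do not differ: the same change on two cores in this assay, a 1.4-fold lower number (0.14 log units; within the scatter) from compound 1 to compound 3 and a 1.7-fold lower number (0.22 log units; within the scatter) from compound 2 to compound 4, 1.2-fold (0.08 log units) apart, within the scatter of two such steps. This shows that the change carries between these two aniline parts without a detectable difference in step size, but each step on its own stays within the scatter, so the data do not separate chloro from fluoro on either core, and two cores are too few to support a rule for the whole series.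

The compounds shown leave open whether another group in the place of the halogen, such as bromo, methyl or trifluoromethyl, would give a step beyond the scatter. Also open, as far as these compounds go, is whether the same change would carry to a core whose aniline part holds an amine or a carboxylic acid instead of the methoxy groups.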